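The compounds below may be only part of what the source reports. "The series", "measured", "known", "first", "only" and "open" are said of these compounds alone.

Compound 1 `Cc1cccnc1-c1ccccc1OCC1=NCCN1`: in a functional assay for activation of Alpha-1B adrenergic receptor (Homo sapiens), read by calcium flux (on this read-out higher numbers stand for an effect only at larger amounts of compound and lower numbers for an effect already at smaller amounts), compound 1 gives only a limit of < 100000 nM. Compound 2 `c1ccc(-c2cc[nH]n2)c(OCC2=NCCN2)c1`: in this assay compound 2 gives 79.4 nM.

Among the compounds with values here, compound 2 thus holds the only real number among the two values; the other is a limit, as the limit of < 100000 nM in this assay, at which 1 of the 2 values shown sits, shows. Compound 3 `Cc1cnsc1-c1ccccc1OCC1=NCCN1` differs from compound 2 by 4-methyl-1,2-thiazol-5-yl in place of 1H-pyrazol-3-yl on an aromatic carbon. Within the data shown here, no step between two measured compounds is available to size this change, so the expectation rests on the change alone. Compound 3 is expected to be weaker in this assay, by a step of a 10-fold higher number from compound 2 to compound 3 (1.00 log units; beyond the scatter). The estimated value for compound 3 is 800 nM, expected to fall between 150 nM and 5000 nM.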

Compound 3, half-maximal effective concentration: < 100000 nM
Compound 3 ended at the assay's limit; the forecaster's own chance of this, stated with the estimate: 20%; the middle value lies beyond the limit too.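

Compound 3 gives only a limit in this assay, and the size of the step from compound 2 to compound 3 cannot be read. Left open is how far 4-methyl-1,2-thiazol-5-yl in place of 1H-pyrazol-3-yl shifts this read-out.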